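Trimming the Chain on the Core Nitrogen

The source may report more compounds than this note shows. Statements on the series, on what has been measured and on what is new or still open speak of the compounds shown alone.

Compound 2 `COc1cc(Cc2nc3c(N)ncnc3n2CC(C)C)cc(OC)c1OC` is a trimethoxybenzyl-substituted purine-like scaffold carrying an isobutyl group on an aromatic nitrogen. Among the compounds with values here, in a functional assay on MCF7 cells (Homo sapiens) for antiproliferative activity (on this read-out lower numbers stand for stronger inhibition and higher numbers for weaker inhibition), compound 2 gives 97700 nM, the highest number among the two measured compounds; its only neighbour, compound 1 `CCCCn1c(Cc2cc(OC)c(OC)c(OC)c2)nc2c(N)nc(F)nc21`, gives 24000 nM in this assay. Compound 3 `COc1cc(Cc2nc3c(N)ncnc3n2C)cc(OC)c1OC` differs from compound 2 by hydrogen in place of isopropyl on a saturated chain carbon bound to an aromatic nitrogen. Within the data shown here, no measured pair shows this change, so its effect is unknown; the expected step of a 1.1-fold higher number from compound 2 to compound 3 (0.05 log units; within the scatter) is small, not clearly beyond the scatter. Compound 3 is therefore estimated at 110000 nM, within 35000 nM to 350000 nM.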

Compound 3, half-maximal inhibitory concentration: 70800 nM
Compound 3: middle estimate off by 1.6-fold (0.19 log units), on the high side; the range from low to high includes it.
By their numbers in this assay, from the lowest: compound 1; then compounds 3 and 2 (each within the scatter of the next).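

Swapping isopropyl for hydrogen on a saturated chain carbon bound to an aromatic nitrogen gives a 1.4-fold lower number from compound 2 to compound 3 (0.14 log units; within the scatter) in this assay as the first direct reading of a change at this position. Cutting isobutyl down to methyl therefore does not clearly separate the two compounds on this read-out. Nothing available explains this result.
Still open, as far as these compounds go, is whether a longer chain, such as hexyl, or a chain ending in an amine or a carboxylic acid, would move the number beyond the scatter.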